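This account rests on a few compounds, and the source may have more. Where it says the series, first, only, none or still open, it means among the compounds named here.

Compound 1 `CNC(=O)c1cc(-c2cnc(NCc3c(F)ccc4c3CCO4)c3cn[nH]c(=O)c23)n(C)n1` was run in an ADME assay on microsomes from liver (Homo sapiens) for metabolic stability, read by LC-MS, using NADPH, with stated times of 5 min and 30 min, tested at 1 uM; on this read-out higher numbers stand for fast clearance and lower numbers for slow clearance. In this assay compound 1 gives only a limit, < 3 mL.min-1.g-1, not a number. Compound 1 thus accounts for (the limit of < 3 mL.min-1.g-1 in this assay, at which 1 of the 2 values shown sits). Going by the values given here, compound 2 `O=C1c2ccccc2CN1c1cnc(NCc2c(F)ccc3c2CCO3)n2cnnc12` gives 13 mL.min-1.g-1 in this assay, and this is the only real number among the values shown, so compound 2 stands alone as the reference point. Among the compounds with values here, no step between two measured compounds is available. Compound 3 `CN(C(=O)c1ccccc1)c1cnc(NCc2c(F)ccc3c2CCO3)n2cnnc12` has not yet been measured; it differs from compound 2 in one place (a group of 10 heavy atoms (8 carbon, 1 nitrogen, 1 oxygen; one six-membered aromatic ring of carbon only) in place of a group of 10 heavy atoms (8 carbon, 1 nitrogen, 1 oxygen; one five-membered non-aromatic ring with 1 hetero atom, one six-membered aromatic ring of carbon only), on an aromatic carbon). The group of one five-membered non-aromatic ring with 1 hetero atom fused to one six-membered aromatic ring of carbon only gives way to an open benzoyl(methyl)amino group. With nothing measured to lean on, the expected step is small, a 1.2-fold higher number from compound 2 to compound 3 (0.06 log units; within the scatter), no more than the usual scatter. Compound 3 is estimated at 15 mL.min-1.g-1, with a likely range from 6 mL.min-1.g-1 to 35 mL.min-1.g-1.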

Compound 3, intrinsic clearance in microsomes: > 300 mL.min-1.g-1
Compound 3: only a limit was reported (the forecaster's own chance of this, stated with the estimate: 10%); middle value at least 20-fold (1.30 log units) from the limit.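

In this assay, opening the five-membered ring of compound 2 into the benzoyl(methyl)amino group on the same aromatic carbon gives an at least 23-fold higher number from compound 2 to compound 3 (1.36 log units; beyond the scatter). The two groups have the same counts of heavy atoms, hydrogen-bond acceptors and double bonds outside aromatic rings, so these counts alone do not predict clearance at this position; the closed ring is what separates the two groups. Compound 3 gives only a limit, not a number, so the true size of the step remains unknown: the limit of > 300 mL.min-1.g-1 in this assay, at which 1 of the 3 values shown sits.

The compounds shown leave open whether the high number goes with the methyl on the amide nitrogen, the benzene ring of the benzoyl group or the open form as a whole. A benzoylamino group without that methyl, or an acetyl(methyl)amino group, in the same place would help to separate these possibilities.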